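The source may report more compounds than this note shows. Statements on the series, on what has been measured and on what is new or still open speak of the compounds shown alone.

Compound 1 `Oc1ccc(-c2cc(-c3cccs3)cc(-c3ccc(O)cc3)n2)cc1`: in a functional assay on HCT-15 cells (Homo sapiens) for cytotoxicity, read by CCK-8 assay (a higher number here means a weaker inhibitor, a lower number a stronger inhibitor), compound 1 gives > 50000 nM, which is a limit of the assay rather than a number.
Compound 2 `Oc1ccc(-c2cc(-c3ccco3)cc(-c3ccc(O)cc3)n2)cc1`: in this assay compound 2 gives 14000 nM.
Compound 3 `Oc1ccc(-c2cc(-c3cccnc3)cc(-c3ccccc3O)n2)cc1`: in this assay compound 3 gives > 50000 nM, which is again a limit of the assay rather than a number.

On these data alone, compound 3 therefore stands at the limit of > 50000 nM in this assay, at which 2 of the 3 values shown sit, so its true value is unknown beyond that limit. For the measured compounds named here, the only change with a measured step is an at least 3.5-fold lower number from compound 1 to compound 2 (0.55 log units; beyond the scatter), which swaps one five-membered ring for another and does not touch the hydroxyphenyl groups.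

Compound 4 `Oc1ccc(-c2cc(-c3cccnc3)cc(-c3ccc(O)cc3)n2)cc1` differs from compound 3 by 4-hydroxyphenyl in place of 2-hydroxyphenyl on an aromatic carbon. Going by the values given here, no measured step covers this change, so there is nothing to read its size from; the shared core of compound 2 with two 4-hydroxyphenyl groups is the only compound with a measured number. Compound 4 is expected to give an estimated 30000 nM with a likely range from 8000 nM to 100000 nM. This estimate means an expected step of an at least 1.6-fold lower number from compound 3 to compound 4 (0.22 log units; that floor lies within the scatter), with a real chance that only a limit is reported again.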

Compound 4, half-maximal inhibitory concentration: 840 nM
For compound 4 the middle estimate is 36-fold (1.55 log units) above the measured one; measured number below the stated range.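

Swapping 2-hydroxyphenyl for 4-hydroxyphenyl on the carbon next to the ring nitrogen gives an at least 59-fold lower number from compound 3 to compound 4 (1.77 log units; beyond the scatter), so with the same atoms joined differently, this one position separates an inactive-looking compound from the strongest of the four. The third ring also matters far more than the furan and thiophene pair suggested: with 4-hydroxyphenyl groups on both sides, pyridin-3-yl in place of furan-2-yl gives a 17-fold lower number from compound 2 to compound 4 (1.22 log units; beyond the scatter), and pyridin-3-yl in place of thiophen-2-yl gives an at least 59-fold lower number from compound 1 to compound 4 (1.77 log units; beyond the scatter). Steps starting from compound 1 or compound 3 are only minimum sizes, as each of these two compounds sits at a limit of the assay: the limit of > 50000 nM in this assay, at which 2 of the 4 values shown sit.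

The compounds shown leave open how a 3-hydroxyphenyl or a 4-methoxyphenyl group would read at this position. They also leave open whether pyridin-4-yl would serve as well as pyridin-3-yl.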